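Indolyl swap at the bicyclic core: compound 3 to compound 4

This account rests on a few compounds, and the source may have more. Where it says the series, first, only, none or still open, it means among the compounds named here.

Measured so far:
- compound 1, `COc1cc(-c2ccnc3cc(-c4ccc(C)cc4)nn23)cc(OC)c1OC`: 21 nM
- compound 2, `COc1cc(-c2ccnc3cc(-c4ccc5ccn(C)c5c4)nn23)cc(OC)c1OC`: 657 nM
- compound 3, `COc1cc(-c2ccnc3cc(-c4ccc(N(C)C)cc4)nn23)cc(OC)c1OC`: 702 nM

In a functional assay on B16-F0 cells (Mus musculus) for inhibition, read by CCK-8 assay, with a stated time of 48 h (on this read-out lower numbers stand for stronger inhibition and higher numbers for weaker inhibition), compound 3 gives the highest of the three numbers; it sits within the scatter of compound 2 and far from compound 1, as the step of a 33-fold higher number from compound 1 to compound 3 (1.52 log units; beyond the scatter) shows. The change to compound 4, `COc1cc(-c2ccnc3cc(-c4cn(C)c5ccccc45)nn23)cc(OC)c1OC`, is 1-methyl-1H-indol-3-yl in place of 4-(dimethylamino)phenyl on an aromatic carbon.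

Within the data shown here, two measured steps bear on this. The step of a 31-fold higher number from compound 1 to compound 2 (1.50 log units; beyond the scatter) shows that a 1-methyl-1H-indol-6-yl at this position gives a number close to that of compound 3, and the step of a 1.1-fold higher number from compound 2 to compound 3 (0.03 log units; within the scatter) confirms the two lie within the scatter. Among the measured compounds shown here, no measured step covers a 1-methyl-1H-indol-3-yl, so its attachment through the five-membered ring is untested. The expectation is therefore a step of a 1.4-fold lower number from compound 3 to compound 4 (0.15 log units; within the scatter) in this assay, not beyond the scatter, with a slight lean toward a lower number because compound 2 gives 657 nM with a related indolyl group. Compound 4 is expected to give about 500 nM, in the range 150 nM to 1600 nM.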

Compound 4, half-maximal inhibitory concentration: 185 nM
The estimate for compound 4 lay 2.7-fold (0.43 log units) above the measured number; the measured number falls inside the stated range.
By their numbers in this assay, from the lowest: compound 1; then compound 4; then compounds 2 and 3 (each within the scatter of the next).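

In this assay, the point of attachment of the indole counts at this position: 1-methyl-1H-indol-3-yl and 1-methyl-1H-indol-6-yl are not interchangeable on the shared core (a 3.6-fold lower number from compound 2 to compound 4 (0.55 log units; beyond the scatter)). The 1-methyl-1H-indol-3-yl also separates from 4-(dimethylamino)phenyl (a 3.8-fold lower number from compound 3 to compound 4 (0.58 log units; beyond the scatter)), a separation the 1-methyl-1H-indol-6-yl did not give, yet it stays short of the 4-methylphenyl of compound 1 (an 8.8-fold higher number from compound 1 to compound 4 (0.94 log units; beyond the scatter)). No measurement at hand accounts for these differences.

Going by these compounds, it remains open whether the unmethylated 1H-indol-3-yl, with a hydrogen on the indole nitrogen, would keep the number of compound 4. Also open is whether a 4-chlorophenyl or 4-ethylphenyl at this position would come closer to compound 1 than any indolyl group shown here.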